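Replacing an aryloxymethyl arm with a sulfamoylthiophene

A few compounds are considered here, and "the series" means these few. Any claim that something is new, unique, unknown or untested is made for them only; others in the source may bear on it.

Compounds measured so far:
compound 1, `Cc1ccc(OCc2ccccc2-c2nc(-c3cc(Cl)sc3S(N)(=O)=O)cs2)cc1`: 68.7%
compound 2, `NS(=O)(=O)c1sc(Cl)cc1-c1csc(-c2ccccc2COc2ccc(Cl)cc2)n1`: 76.4%
compound 3, `Cc1ccccc1OCc1ccccc1-c1nc(COc2ccc(Cl)cc2)cs1`: 65.1%

In a functional assay on the whole organism (strain Wistar albino) for inhibition, with Rattus norvegicus as the target, read by paw edema, at a dose of 10 mg/kg by the oral route (a higher number here means more inhibition at the dose given (going by the name of the read-out), a lower number less inhibition), compound 3 stands lowest of the three numbers. Its nearest neighbour is compound 1, which lies higher by an amount within the scatter, while compound 2 lies higher by an amount beyond the scatter. Going by the values given here, the only step between compounds differing in one place is a number 7.7 percentage points higher from compound 1 to compound 2 (within the scatter), which is within the scatter.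

Compound 4, `Cc1ccccc1OCc1ccccc1-c1nc(-c2cc(Cl)sc2S(N)(=O)=O)cs1`, is not yet measured. It differs from compound 3 by 5-chloro-2-sulfamoylthiophen-3-yl in place of (4-chlorophenoxy)methyl on an aromatic carbon. Among the compounds with values here, no measured step bears directly on this exchange; the one step in hand, from compound 1 to compound 2, concerns a different part of the molecule. What the data do show is that both compound 1 and compound 2 carry the 5-chloro-2-sulfamoylthiophen-3-yl group; in this assay compound 1 gives 68.7% and compound 2 gives 76.4%, whereas compound 3 stands lowest of the three. The step of a number 4.9 percentage points higher from compound 3 to compound 4 (within the scatter) is therefore expected to be small and upward, not clearly beyond the scatter. Compound 4 is estimated at 70%, with a range from 60% to 80%.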

Compound 4, a percentage reported as inhibition, in the whole organism at one dose (the size of the read-out at that dose, not a potency): 70.1%
Compound 4: the middle estimate sits 0.1 percentage points below what was measured; measured number inside the range.
By their numbers in this assay, from the lowest: compounds 3, 1, 4 and 2 (each within the scatter of the next, the first and the last beyond it).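

In this assay, putting 5-chloro-2-sulfamoylthiophen-3-yl in place of (4-chlorophenoxy)methyl on the aromatic carbon next to the ring nitrogen gives a number 5 percentage points higher from compound 3 to compound 4 (within the scatter), so this position takes either group without a change beyond the scatter. The new compound also opens the aryl ether arm to comparison: 2-methylphenyl in place of 4-methylphenyl on the oxygen gives a number 1.4 percentage points higher from compound 1 to compound 4 (within the scatter), and 2-methylphenyl in place of 4-chlorophenyl gives a number 6.3 percentage points lower from compound 2 to compound 4 (within the scatter). With the sulfamoylthiophene in place, all three aryl groups on that oxygen therefore lie within the scatter of one another.

Nothing in the data gives a cause for any of these steps. As far as these compounds go, whether an amine or a carboxylic acid at this position would keep the read-out in the same range remains open.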